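The source may hold more compounds than are shown below. What is called first, only, known or untested is meant among the compounds shown, and "the series" means these compounds.

Compound 1 `CC1=CC[C@H](C(C)(C)NC(=S)N/N=C/c2ccccc2)CC1` and compound 2 `CC1=CC[C@H](C(C)(C)NC(=S)N/N=C/c2cccc(Cl)c2)CC1` share one core and differ at a single aromatic carbon. In a functional assay on OVCAR-3 cells (Homo sapiens) for inhibition, read by sulforhodamine B assay, with a stated time of 48 h (on this read-out lower numbers stand for stronger inhibition of growth and higher numbers for weaker inhibition of growth), compound 1 gives 8700 nM, and compound 2 gives 13600 nM; the step between them is a 1.6-fold higher number from compound 1 to compound 2 (0.19 log units; within the scatter). Compound 2 thus holds the higher of the two numbers in this assay, though the gap to compound 1 lies within the scatter. Compound 3 `CC1=CC[C@H](C(C)(C)NC(=S)N/N=C/c2cccc([N+](=O)[O-])c2)CC1` follows from compound 2 by one change: nitro in place of chloro on an aromatic carbon. For the measured compounds named here, no measured pair shows a nitro entering in place of a chloro, so the only step that bears on this change is the one at the same aromatic carbon, a 1.6-fold higher number from compound 1 to compound 2 (0.19 log units; within the scatter), which stayed within the scatter. On that basis the step in this assay is expected to be small, a 1.1-fold lower number from compound 2 to compound 3 (0.05 log units; within the scatter), with no direction foreseen beyond the scatter. Compound 3 is therefore estimated at 12000 nM in this assay, with a range from 5000 nM to 30000 nM.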

Compound 3, concentration for 50% growth inhibition: > 100000 nM
Compound 3 ended at the assay's limit; the forecaster's own chance of this, stated with the estimate: 10%; middle value at least 8.3-fold (0.92 log units) away from the limit.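

In this assay, compound 3 stands at a limit and not at a measured number: the limit of > 100000 nM in this assay, at which 1 of the 3 values shown sits. Chloro in place of hydrogen at this aromatic carbon gave only a 1.6-fold higher number from compound 1 to compound 2 (0.19 log units; within the scatter), so the earlier pair gave no sign that this position responds to what sits there. Nitro shows that it does: nitro in place of chloro gives an at least 7.3-fold higher number from compound 2 to compound 3 (0.86 log units; beyond the scatter), and nitro in place of hydrogen gives an at least 11-fold higher number from compound 1 to compound 3 (1.06 log units; beyond the scatter), both toward weaker inhibition of growth and both only lower bounds on the true step.

As far as these compounds go, how far growth inhibition falls with nitro at this carbon therefore stays open. Also open, from the compounds shown here alone, are how an amine or a methoxy group would read at the same carbon, and whether nitro at another carbon of the ring would give a similar step.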